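A Chlorophenyl Amide Weighed Against Its Methylphenyl Parent

The source may report more compounds than this note shows. Statements on the series, on what has been measured and on what is new or still open speak of the compounds shown alone.

The account starts from compound 1 `CCCCc1nc(Cl)c(C2NC(=O)NC(C)=C2C(=O)Nc2cccc(C)c2)[nH]1`, a dihydropyrimidinone carboxamide bearing a butyl-substituted chloroimidazole. In an ADME assay on Vero cells (Chlorocebus sabaeus) for cytotoxicity, read by MTT assay, with a stated time of 72 h (on this read-out higher numbers stand for weaker inhibition and lower numbers for stronger inhibition), compound 1 gives "not determined" (no result reported), so no number stands for it on this read-out. Two relatives share its core. Compound 2 `CCCCc1nc(Cl)c(C2NC(=O)NC(C)=C2C(=O)Nc2ccccc2F)[nH]1` in this assay gives > 10 ug/mL, which is a limit of the assay and not a number. Compound 3 `CCCCc1nc(Cl)c(C2NC(=O)NC(C)=C2C(=O)Nc2ccccc2[N+](=O)[O-])[nH]1` in this assay gives "not determined" (no result reported). Within the data shown here, compound 1 therefore stands among the entries without a single number, and the only measured information in the set is the limit of > 10 ug/mL in this assay, at which 1 of the 3 values shown sits.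

Compound 4 `CCCCc1nc(Cl)c(C2NC(=O)NC(C)=C2C(=O)Nc2ccc(Cl)cc2)[nH]1` has not been measured. It differs from compound 1 by 4-chlorophenyl in place of 3-methylphenyl on an amide-type nitrogen. Among the measured compounds shown here, no step between two measured compounds is available, so the size of the move in this assay from compound 1 to compound 4 cannot be read from the data; the writer expects no step beyond the scatter in either direction. Compound 4 is expected to behave like compound 2 and to reach the limit rather than a number, due to the limit of > 10 ug/mL in this assay, at which 1 of the 3 values shown sits. The writer estimates for compound 4 a value of 12 ug/mL, with a range from 5 ug/mL to 30 ug/mL.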

Compound 4, half-maximal inhibitory concentration: 9.4 ug/mL
For compound 4 the middle estimate is 1.3-fold (0.11 log units) above the measured one, and the stated range covers the measured number.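

In this assay, among these compounds, compound 4 gives the first single number of the set, which shows that a readable value can be had on the shared core with 4-chlorophenyl on the amide-type nitrogen. Among the compounds shown here, with 4-chlorophenyl in place of 2-fluorophenyl at that nitrogen, the data give an at least 1.0-fold lower number from compound 2 to compound 4 (0.02 log units; that floor lies within the scatter) and so set no order between the two compounds, while compound 1 and compound 3 have no result on this read-out and no step from either of them can be read. The step has only a floor because compound 2 stands at a limit and not at a number: the limit of > 10 ug/mL in this assay, at which 1 of the 4 values shown sits.

What the compounds shown leave open is whether an amine or a carboxylic acid on the phenyl ring of the amide would move the number in this assay beyond the usual scatter. It also remains open how a longer chain in place of the butyl group would read on this core, since every compound shown carries the same butyl chain.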